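A few compounds are considered here, and "the series" means these few. Any claim that something is new, unique, unknown or untested is made for them only; others in the source may bear on it.

Working notes on the thioenone series in a functional assay on DU-145 cells (Homo sapiens) for inhibition, read by trypan blue exclusion, with a stated time of 96 h; a lower number here means a stronger inhibitor of growth, a higher number a weaker inhibitor of growth.

Compound 1 `Cc1ccc(S/C(=C/c2ccc(N(C)C)cc2)C(=O)c2ccc(Cl)cc2)cc1` carries a 4-(dimethylamino)phenyl on the double-bonded chain carbon and a chloro on the aromatic carbon of the carbonyl-bearing ring. In this assay compound 1 gives only a limit of the assay, > 100000 nM.

Compound 2 `Cc1ccc(S/C(=C/c2c(O)cc(O)cc2O)C(=O)c2ccc(Cl)cc2)cc1` differs from compound 1 by 2,4,6-trihydroxyphenyl in place of 4-(dimethylamino)phenyl on a double-bonded chain carbon bound to a double-bonded chain carbon. In this assay compound 2 likewise gives only a limit, > 100000 nM. The step that the two limits leave unreadable from compound 1 to compound 2 is therefore not readable in either direction.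

Compound 3 `Cc1ccc(S/C(=C/c2ccc(N(C)C)cc2)C(=O)c2ccc(Br)cc2)cc1` is the bromo counterpart of compound 1. In this assay compound 3 again gives only a limit, > 100000 nM. The step that the two limits leave unreadable from compound 1 to compound 3 is equally unreadable. All three values rest at the same point, (the limit of > 100000 nM in this assay, at which 3 of the 3 values shown sit), so no order among compounds 1, 2 and 3 can be drawn, and no pattern beyond these three is claimed.

Compound 4 `Cc1ccc(S/C(=C/c2c(O)cc(O)cc2O)C(=O)c2ccc(Br)cc2)cc1` is not yet measured. It differs from compound 3 by 2,4,6-trihydroxyphenyl in place of 4-(dimethylamino)phenyl on a double-bonded chain carbon bound to a double-bonded chain carbon. The place is the same word for word as in the change from compound 1 to compound 2, so this is the same change, made on the other core; the two cores differ by bromo in place of chloro on an aromatic carbon. The earlier instance of the change gave no readable size. Compound 4 is expected to give a step that the limit leaves unreadable from compound 3 to compound 4, which rests on compound 2 sitting at the limit of > 100000 nM in this assay, at which 3 of the 3 values shown sit. Compound 4 is estimated at 200000 nM, with the expected range 50000 nM to 1000000 nM, most likely reported as a limit.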

Compound 4, concentration for 50% growth inhibition: > 100000 nM
Compound 4 ended at the assay's limit; the forecaster's own chance of this, stated with the estimate: 85%; the middle value lies beyond the limit too.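

In this assay compound 4 gives > 100000 nM, which is a limit of the assay. No new step can be read from compound 3 or compound 2 to compound 4, and the series offers no value to compare: the limit of > 100000 nM in this assay, at which 4 of the 4 values shown sit.

The compounds shown leave open whether either change, the bromo for chloro or the 2,4,6-trihydroxyphenyl for 4-(dimethylamino)phenyl, alters growth inhibition at all.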